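The source may hold more compounds than are shown below. What is called first, only, known or untested is meant among the compounds shown, and "the series" means these compounds.

Measured compounds:
- compound 1 `Nc1nc(N2CCN(C3CCCC3)CC2)c2ncn(CCCN3CCCC3)c2n1`: 120 nM
- compound 2 `CCN1CCN(CCCn2cnc3c(N4CCN(CC)CC4)nc(N)nc32)CC1`: 260 nM
- compound 3 `CCN1CCN(CCCn2cnc3c(N4CCN(C5CCCC5)CC4)nc(NC(=O)c4ccc(CN(C)C)cc4)nc32)CC1`: 60 nM

In an assay on HEK293 cells for antagonist activity at Toll-like receptor 9 (Homo sapiens), read by spectrophotometry (on this read-out higher numbers stand for weaker inhibition and lower numbers for stronger inhibition), compound 3 gives the lowest of the three numbers. Compound 1 sits close to it, within the usual scatter, so the two cannot be ranked against each other; compound 2 lies further off, beyond the scatter, and so shows weaker inhibition than compound 3.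

Compound 4 `CCN1CCN(CCCn2cnc3c(N4CCN(C5CCCC5)CC4)nc(N)nc32)CC1` has not yet been measured in this assay. It differs from compound 3 in one place: hydrogen in place of (4-((dimethylamino)methyl)phenyl)carbonyl on a nitrogen on an aromatic ring. Compound 4 thus carries hydrogen at that nitrogen, as compound 1 and compound 2 do, and both of those give higher numbers than compound 3, with the value of compound 1 in this assay being 120 nM and that of compound 2 being 260 nM.

On that basis compound 4 is expected to land near the other two hydrogen-bearing compounds, so the estimated step of a 2.5-fold higher number from compound 3 to compound 4 (0.40 log units; beyond the scatter) points toward weaker inhibition, of a size at the edge of the scatter. The expected value for compound 4 is 150 nM, with a range of 60 nM to 400 nM.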

Compound 4, half-maximal inhibitory concentration: 280 nM
Compound 4: middle estimate off by 1.9-fold (0.27 log units), on the low side; measured number inside the range.
By their numbers in this assay, from the lowest: compounds 3 and 1 (each within the scatter of the next); then compounds 2 and 4 (each within the scatter of the next).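

In this assay, hydrogen in place of (4-((dimethylamino)methyl)phenyl)carbonyl on the aromatic-ring nitrogen gives a 4.7-fold higher number from compound 3 to compound 4 (0.67 log units; beyond the scatter), a modest step showing that, in this pair that differs in one place only, the compound carrying the larger group inhibits more strongly. Cyclopentyl in place of ethyl on the ring amine nitrogen gives a 1.1-fold higher number from compound 2 to compound 4 (0.03 log units; within the scatter), so that pair cannot be ranked, whereas 4-ethylpiperazin-1-yl in place of pyrrolidin-1-yl on the saturated chain gives a 2.3-fold higher number from compound 1 to compound 4 (0.37 log units; beyond the scatter), a modest step towards weaker inhibition. Nothing shown here explains either modest step.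

Within the data shown here, only one group is compared with hydrogen at the aromatic-ring nitrogen, so it remains open how a plain acetyl or an unsubstituted benzoyl would read there. From the compounds shown here alone, it also remains open how a morpholine or a piperidine would compare on the chain.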